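Methoxy for Hydroxyamino: Estimating Compound 4

The compounds below may be only part of what the source reports. "The series", "measured", "known", "first", "only" and "open" are said of these compounds alone.

Compound 1 `Cc1cc2cc(NS(=O)(=O)c3cc(C(=O)NO)ccc3Cl)ccc2n(C)c1=O` gives 29% in a functional assay on HL-60 cells (Homo sapiens) for antiproliferative activity, tested at 4 uM; on this read-out higher numbers stand for a stronger effect at the one concentration tested and lower numbers for a weaker effect.
Compound 2 `COc1ccc(C(=O)NO)cc1NCc1ccc(OCCCCC(=O)Nc2ccc3c(c2)cc(C)c(=O)n3C)cc1` gives 0% in this assay.
Compound 3 `COc1ccc(C(=O)NO)cc1S(=O)(=O)Nc1ccc2c(c1)cc(C)c(=O)n2C` gives 25% in this assay.

Compound 3 stands second highest of the three numbers: the step of a number 4 percentage points lower from compound 1 to compound 3 (within the scatter) lay within the scatter, while compound 2 sits well below compound 3, beyond the scatter. Compound 4 `COC(=O)c1ccc(OC)c(S(=O)(=O)Nc2ccc3c(c2)cc(C)c(=O)n3C)c1` differs from compound 3 in one place: methoxy in place of hydroxyamino on a carbonyl carbon. Within the data shown here, no measured step exchanges these groups; the only measured step, a number 4 percentage points lower from compound 1 to compound 3 (within the scatter), concerns methoxy in place of chloro on an aromatic carbon and offers no guide to this change. The estimate therefore rests on compound 3 alone. Compound 4 is expected to give 8%, with a range from 0% to 22%. This estimate means an expected step of a number 17 percentage points lower from compound 3 to compound 4 (beyond the scatter), a loss beyond the scatter.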

Compound 4, a percentage reported as inhibition, at one concentration (the size of the read-out at that concentration, not a potency): 39%
Compound 4: the middle estimate sits 31 percentage points below what was measured, and the stated range ends below it.
By their numbers in this assay, from the lowest: compound 2; then compounds 3, 1 and 4 (each within the scatter of the next, the first and the last beyond it).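

In this assay, putting methoxy in place of hydroxyamino on a carbonyl carbon gives a number 14 percentage points higher from compound 3 to compound 4 (beyond the scatter) and so shows that, at this one concentration, the effect does not depend on hydroxycarbamoyl being present. Methoxycarbonyl serves here at least as well, even though methoxy counts 0 hydrogen-bond donors. No measurement shown explains this rise. Going by these compounds, it remains open whether hydroxy or amino on the same carbonyl carbon would match methoxy, and whether the same exchange on compound 1 would move the number the same way.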